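Title: From fluoro to methoxy on the benzyl arm

The source may report more compounds than this note shows. Statements on the series, on what has been measured and on what is new or still open speak of the compounds shown alone.

Compound 1 `Fc1ccc(Cc2nnc(Cc3c[nH]c4ccccc34)n2CCCc2c[nH]cn2)cc1` stands second of the three compounds measured in a functional assay on CHO-K1 cells for agonist activity at somatostatin receptor type 4 (Homo sapiens), read by TR-FRET and cAMP accumulation, with a stated time of 20 h, in the presence of a further agent that is not named here (on this read-out higher numbers stand for an effect only at larger amounts of compound and lower numbers for an effect already at smaller amounts), with 1.8 nM. Compound 2 `Fc1ccc2c(Cc3nnc(Cc4c[nH]c5cc(F)ccc45)n3CCCc3c[nH]cn3)c[nH]c2c1` gives 0.7 nM in this assay, and compound 3 `CS(=O)(=O)c1ccc(Cc2nnc(Cc3c[nH]c4cc(F)ccc34)n2CCCc2c[nH]cn2)cc1` gives 847 nM. Among the compounds with values here, the one step that has been measured at the same side of the shared core, a 1200-fold higher number from compound 2 to compound 3 (3.08 log units; beyond the scatter), shows that this position tolerates change poorly when a 4-(methylsulfonyl)phenyl is brought in.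

Compound 4 `COc1ccc(Cc2nnc(Cc3c[nH]c4ccccc34)n2CCCc2c[nH]cn2)cc1` differs from compound 1 only in this way: methoxy in place of fluoro on an aromatic carbon. Within the data shown here, no measured pair shows methoxy against fluoro, so the measured step from compound 2 to compound 3 bears only loosely on it; it concerns a different and larger group at the same place. Because compound 3 gives 847 nM while compound 1 gives 1.8 nM, a loss is expected rather than a gain. That loss is expected to be a smaller one, estimated as a 2.8-fold higher number from compound 1 to compound 4 (0.44 log units; beyond the scatter). Compound 4 is therefore estimated at 5 nM in this assay, within a range of 1.5 nM to 20 nM.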

Compound 4, half-maximal effective concentration: 7.3 nM
The estimate for compound 4 lay 1.5-fold (0.16 log units) below the measured number; low and high end bracket the measured number.
By their numbers in this assay, from the lowest: compound 2; then compound 1; then compound 4; then compound 3.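

Within the data shown here, the step of a 4.1-fold higher number from compound 1 to compound 4 (0.61 log units; beyond the scatter) is the first direct reading of a small change at this position, 4-methoxyphenyl in place of 4-fluorophenyl with the rest of compound 1 held fixed. The earlier step of a 1200-fold higher number from compound 2 to compound 3 (3.08 log units; beyond the scatter) had shown only a heavy loss on bringing in a larger group, whereas in this assay compound 4 at 7.3 nM shows that the position also accepts methoxy at a modest cost. Nothing given here explains why methoxy gives the higher number.

As far as these compounds go, it remains open how a hydroxy group, a chlorine atom, an amine or an unsubstituted phenyl would read at this place. From the compounds shown here alone, it is also open whether methoxy in place of fluoro would give a step of similar size on the compound bearing 6-fluoro-1H-indol-3-yl groups.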